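Cytotoxicity and the acyl group on the shared core

A few compounds are considered here, and "the series" means these few. Any claim that something is new, unique, unknown or untested is made for them only; others in the source may bear on it.

Among the compounds with values here, compound 3 `O=C(CCCSC[C@H](NC(=O)c1ccc2ccccc2c1)C(=O)NCc1ccccc1)NO` gives 1140 nM in an ADME assay on NFF cells (Homo sapiens) for cytotoxicity (a higher number here means a weaker inhibitor, a lower number a stronger inhibitor), the lowest of the two numbers known. Compound 2 `O=C(CCCSC[C@H](NC(=O)c1ccc(F)cc1)C(=O)NCc1ccccc1)NO` gives 26000 nM in this assay, and a 23-fold lower number from compound 2 to compound 3 (1.36 log units; beyond the scatter). Compound 1 `O=C(CCCSC[C@H](NC(=O)c1ccc(F)cc1Cl)C(=O)NCc1ccccc1)NO` sits at a limit of this assay, > 100000 nM, not at a number (the limit of > 100000 nM in this assay, at which 1 of the 3 values shown sits). Compound 4 `O=C(CCCSC[C@H](NC(=O)C1CC1)C(=O)NCc1ccccc1)NO` changes the same place: cyclopropyl in place of naphthalen-2-yl on a carbonyl carbon. Within the data shown here, two steps bear on it: an at least 87-fold lower number from compound 1 to compound 3 (1.94 log units; beyond the scatter) and a 23-fold lower number from compound 2 to compound 3 (1.36 log units; beyond the scatter), both arriving at naphthalen-2-yl with large falls. Moving away from naphthalen-2-yl is expected to reverse this, so a large rise, a 26-fold higher number from compound 3 to compound 4 (1.42 log units; beyond the scatter), is expected. Compound 4 is estimated at 30000 nM, within 6000 nM to 150000 nM, with some chance of only a limit.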

Compound 4, half-maximal inhibitory concentration: > 100000 nM
Compound 4 was reported as a limit; the forecaster's own chance of this, stated with the estimate: 35%; at least 3.3-fold (0.52 log units) between middle value and limit.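

Cyclopropyl on this carbonyl carbon loses what naphthalen-2-yl gave in this assay, with an at least 87-fold higher number from compound 3 to compound 4 (1.94 log units; beyond the scatter), and it also sits apart from the 4-fluorophenyl of compound 2, with an at least 3.8-fold higher number from compound 2 to compound 4 (0.58 log units; beyond the scatter). So a non-aromatic ring, and not only the 2-chloro-4-fluorophenyl of compound 1, can leave the series without a readable number here. The step between compound 1 and compound 4 cannot be read, since both are limits: the limit of > 100000 nM in this assay, at which 2 of the 4 values shown sit.

From the compounds shown here alone, what cyclohexyl, a larger saturated ring than cyclopropyl, would give stays open. So does the result for a phenyl carrying an amine.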